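The source may report more compounds than this note shows. Statements on the series, on what has been measured and on what is new or still open speak of the compounds shown alone.

In a functional assay on U-251 cells (Homo sapiens) for inhibition, read by sulforhodamine B assay, with a stated time of 48 h, tested at 10 uM (on this read-out lower numbers stand for less inhibition and higher numbers for more inhibition at the one concentration tested (going by the name of the read-out)), the measured compounds stand as follows:

compound 1 `c1ccc(-c2cn3ccnc3c(-c3ccc4ncn(C5CCCCC5)c4c3)n2)cc1` gives 37.3%
compound 2 `COc1ccccc1-c1cn2ccnc2c(-c2ccc3ncn(C4CCCCC4)c3c2)n1` gives 21%

Compound 2 holds the lower of the two numbers, the change being a number 16.3 percentage points lower from compound 1 to compound 2 (beyond the scatter). Compound 3 `c1csc(-c2cn3ccnc3c(-c3ccc4ncn(C5CCCCC5)c4c3)n2)c1` differs from compound 2 by thiophen-2-yl in place of 2-methoxyphenyl on an aromatic carbon. Among the compounds with values here, no measured step bears directly on this exchange: the single step, a number 16.3 percentage points lower from compound 1 to compound 2 (beyond the scatter), concerns methoxy in place of hydrogen on an aromatic carbon, and the group that enters in compound 3 carries no methoxy. Compound 1, which likewise carries no methoxy, gives 37.3%. On that basis a modest rise is expected for compound 3, roughly a number 9 percentage points higher from compound 2 to compound 3 (within the scatter), though it may well stay within the scatter. Compound 3 is therefore estimated at 30%, with a range from 12% to 48%.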

Compound 3, a percentage reported as inhibition, at one concentration (the size of the read-out at that concentration, not a potency): 3.92%
The estimate for compound 3 lay 26.1 percentage points above the measured number; the measured number lies below the stated range.
By their numbers in this assay, from the lowest: compound 3; then compound 2; then compound 1.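

In this assay, the aromatic carbon next to the ring nitrogen proves sensitive to the ring itself, not only to a methoxy added to it. Replacing 2-methoxyphenyl with thiophen-2-yl gives a number 17.1 percentage points lower from compound 2 to compound 3 (beyond the scatter), and replacing phenyl with thiophen-2-yl gives a number 33.4 percentage points lower from compound 1 to compound 3 (beyond the scatter), so a group without methoxy now gives the lowest number of the three and unsubstituted phenyl remains the highest. The data shown give no reason for either drop.

As far as these compounds go, it remains open whether the fall belongs to the sulfur, to the five-membered ring or to the smaller group as a whole. A furan-2-yl or pyridinyl ring would help separate these, while an amine such as morpholine at this position would test whether an aromatic ring is needed at all.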